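Aryl versus isopropyl on the ring amide nitrogen

The source may report more compounds than this note shows. Statements on the series, on what has been measured and on what is new or still open speak of the compounds shown alone.

Two analogues of the shared core have been run in a functional assay on the whole organism (strain Kunming) with Mus musculus as the target, in the maximal electroshock model, with a stated time of 4 h; on this read-out lower numbers stand for an effect already at smaller amounts and higher numbers for an effect only at larger amounts of compound. Compound 1 `O=C1NC2(CC2c2ccc3cccc(OCc4ccccc4)c3n2)C(=O)N1c1ccc(C(F)(F)F)cc1` gives 300 mg/kg. Among the measured compounds shown here, compound 2 `CC(C)N1C(=O)NC2(CC2c2ccc3cccc(OCc4ccccc4)c3n2)C1=O` gives 100 mg/kg, the lowest of the two numbers recorded so far; the only comparison available is a 3.0-fold lower number from compound 1 to compound 2 (0.48 log units; beyond the scatter), which arises from isopropyl in place of 4-(trifluoromethyl)phenyl on an amide-type nitrogen in a ring.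

Compound 3 `O=C1NC2(CC2c2ccc3cccc(OCc4ccccc4)c3n2)C(=O)N1c1ccc(Br)cc1` has not yet been measured. For the measured compounds named here, its difference from compound 2 is 4-bromophenyl in place of isopropyl on an amide-type nitrogen in a ring, so the change runs in the opposite sense to the one step known: an aromatic substituent returns to the same ring nitrogen, now carrying bromine instead of trifluoromethyl. Going by the values given here, the single bearing step, a 3.0-fold lower number from compound 1 to compound 2 (0.48 log units; beyond the scatter), was of modest size and beyond the scatter, so a move back toward the number of compound 1 in this assay is expected, with the bromine-for-trifluoromethyl swap left open by the data.

Compound 3 is therefore estimated at 250 mg/kg, in the range 100 mg/kg to 600 mg/kg, meaning an expected step of a 2.5-fold higher number from compound 2 to compound 3 (0.40 log units; beyond the scatter).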

Compound 3, minimum effective dose: 300 mg/kg
Estimate against measurement, compound 3: 1.2-fold (0.08 log units) below; low and high end bracket the measured number.
By their numbers in this assay, from the lowest: compound 2; then compounds 1 and 3 (each within the scatter of the next).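

In this assay, 4-bromophenyl in place of isopropyl on the amide-type nitrogen in a ring gives a 3.0-fold higher number from compound 2 to compound 3 (0.48 log units; beyond the scatter), so the lower number of compound 2 now stands against two different aryl groups rather than one. Bromo in place of trifluoromethyl on the aromatic carbon gives no change at the digits printed from compound 1 to compound 3 (within the scatter), so among these three compounds the choice between an aryl group and isopropyl on that nitrogen separates the numbers, while the swap on the phenyl ring does not. Nothing measured here bears on the reason for either step.

Open, on these data alone, is whether the lower number belongs to isopropyl itself or would also appear with other non-aromatic groups on that nitrogen, such as methyl, cyclohexyl or a longer chain like n-butyl. Also open, as far as these compounds go, is whether an unsubstituted phenyl, or a phenyl carrying an amine or a carboxylic acid, would give a number in line with compound 1 and compound 3.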